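From 3-chloropropyl to (chloromethyl)carbonyl in compound 4

The compounds below may be only part of what the source reports. "The series", "measured", "known", "first", "only" and "open" are said of these compounds alone.

In a functional assay on M21 cells (Homo sapiens) for antiproliferative activity, with a stated time of 48 h (on this read-out lower numbers stand for stronger inhibition and higher numbers for weaker inhibition), compound 1 `CC(C)(C)c1ccc(NC(=O)NCCCCl)cc1` gives 35000 nM, compound 2 `CCCCC(O)c1cccc(NC(=O)NCCCCl)c1` gives 35000 nM, and compound 3 `CCCCC(OC)c1cccc(NC(=O)NCCCCl)c1` gives 51000 nM. Compound 3 therefore lies within the scatter of both other compounds, and these three numbers cannot be told apart. Within the data shown here, the one measured step between close relatives is a 1.5-fold higher number from compound 2 to compound 3 (0.16 log units; within the scatter). It comes from methyl in place of hydrogen on an oxygen on a saturated carbon, and it stays within the scatter.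

Compound 4 `CCCCC(OC)c1cccc(NC(=O)NC(=O)CCl)c1` leaves that part of compound 3 untouched and changes another place: (chloromethyl)carbonyl in place of 3-chloropropyl on an amide-type nitrogen. Put simply, this is (chloromethyl)carbonyl in place of 3-chloropropyl on an amide-type nitrogen. Among the measured compounds shown here, all three measured compounds carry the 3-chloropropyl group, so no measured step shows what replacing it does. The small step above therefore offers only weak guidance. This swap alters the chlorine-bearing chain itself and adds a carbonyl, so a step beyond the scatter seems likely, though this is a judgement and not a measured trend. The expected change in this assay is a 6.4-fold lower number from compound 3 to compound 4 (0.80 log units; beyond the scatter), towards stronger inhibition. For compound 4 the estimate is 8000 nM, with an expected range from 2000 nM to 30000 nM.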

Compound 4, half-maximal inhibitory concentration: 4200 nM
Compound 4: the middle estimate sits 1.9-fold (0.28 log units) above what was measured; low and high end bracket the measured number.
By their numbers in this assay, from the lowest: compound 4; then compounds 1, 2 and 3 (each within the scatter of the next).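

In this assay, (chloromethyl)carbonyl in place of 3-chloropropyl on the amide-type nitrogen gives a 12-fold lower number from compound 3 to compound 4 (1.08 log units; beyond the scatter), a large step towards stronger inhibition. The earlier change, methyl in place of hydrogen on the oxygen, gave only a 1.5-fold higher number from compound 2 to compound 3 (0.16 log units; within the scatter), so this is the first change shown with an effect that stands clear of the scatter, and it marks the chlorine-bearing group as a place where the number can move strongly. Nothing at hand speaks to the reason for this drop.

The compounds shown leave open what an acetyl group, which has hydrogen where the (chloromethyl)carbonyl group has chlorine, would give on this nitrogen, and so whether the chlorine matters for the stronger inhibition or the carbonyl alone is enough. Also open, from the compounds shown here alone, are what a longer chain such as 3-chloropropanoyl would give, and whether the same swap produces a step of similar size on the cores of compound 1 and compound 2.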